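The compounds below may be only part of what the source reports. "The series", "measured", "known", "first", "only" and "open" are said of these compounds alone.

Measured so far:
- compound 1 `N/C(=N\NC(=S)N1CCCC1)c1ccc(F)cn1`, giving 50.7%
- compound 2 `N/C(=N\NC(=S)N1CCSCC1)c1ccccn1`, giving 31.7%

Both were tested in a functional assay on A-431 cells (Homo sapiens) for cytotoxicity, read by MTT assay, with a stated time of 72 h, tested at 1 uM; on this read-out higher numbers stand for more inhibition of growth at the one concentration tested and lower numbers for less inhibition of growth. Compound 2 stands lowest of the two numbers; its nearest neighbour, compound 1, gives a higher number, a gap beyond the usual scatter. The two compounds differ in two places at once, so their values say nothing clean about either change on its own.

The next compound, compound 3 `N/C(=N\NC(=S)N1CCSCC1)c1ccc(F)cn1`, keeps everything of compound 2 and changes one thing: fluoro in place of hydrogen on an aromatic carbon. For the measured compounds named here, no measured pair shows this step alone. Going by the values given here, the only hint is that compound 1, which also carries the fluoro, gives 50.7%, but its other ring differs too. A small step upward is expected, a number 6.3 percentage points higher from compound 2 to compound 3 (within the scatter), which may stay within the scatter. Compound 3 is therefore estimated at 38%, with a range from 20% to 58%.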

Compound 3, percent growth inhibition at one concentration: 48.7%
Beside the measured number, compound 3's estimate is 10.7 percentage points below it, within the range that was stated.
By their numbers in this assay, from the lowest: compound 2; then compounds 3 and 1 (each within the scatter of the next).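

In this assay the fluoro in place of hydrogen on an aromatic carbon, para to a large group, can now be read alone, and it gives a modest gain beyond the scatter (a number 17 percentage points higher from compound 2 to compound 3 (beyond the scatter)). With the fluoro present, thiomorpholin-4-yl in place of pyrrolidin-1-yl on a thiocarbonyl carbon leaves the number within the scatter (a number 2 percentage points lower from compound 1 to compound 3 (within the scatter)), so these two rings cannot be told apart here. The data shown offer no measured explanation for the gain from the fluoro.

As far as these compounds go, whether the fluoro gives the same gain alongside pyrrolidin-1-yl remains open, since only the thiomorpholin-4-yl pair shows this step. From the compounds shown here alone, how a chloro, a methoxy or an amine would read at the same aromatic carbon also remains open.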